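Cyclopentyl to Hydroxyethyl on the Amide Nitrogen

The compounds below may be only part of what the source reports. "The series", "measured", "known", "first", "only" and "open" are said of these compounds alone.

The measured set comprises compound 1, `O=C(O)CNC(=O)c1cc2ccccc2oc1=O`, compound 2, `COc1cccc2cc(C(=O)NC3CCCC3)c(=N)oc12`, and compound 3, `O=C(NCCCO)c1cc2ccccc2oc1=O`. In an assay on CHO cells for displacement of a labelled ligand from adenosine receptor A1 (Homo sapiens), read by scintillation counting, with a stated time of 60 min, tested at 10 uM (on this read-out higher numbers stand for more inhibition at the one concentration tested (going by the name of the read-out) and lower numbers for less inhibition), compound 1 gives 1%, and compound 3 gives 24%. For compound 2 the result in this assay is a limit of the assay, > 70%, so only a range is known for where it stands; the relevant point is the limit of > 70% in this assay, at which 1 of the 3 values shown sits. Within the measured set one single-point change is available: a number 23 percentage points higher from compound 1 to compound 3 (beyond the scatter).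

Compound 4, `COc1cccc2cc(C(=O)NCCO)c(=N)oc12`, has not yet been tested in this assay. It differs from compound 2 as follows: 2-hydroxyethyl in place of cyclopentyl on an amide-type nitrogen. Among the compounds with values here, no measured step swaps cyclopentyl for 2-hydroxyethyl on the amide-type nitrogen; the step from compound 1 to compound 3 shows only that a hydroxyl-bearing chain on a related core is compatible with modest inhibition. Within the data shown here, compound 2 starts at a limit, so the size of any step from it cannot be read exactly, and the cyclopentyl it loses has no counterpart among the measured compounds. The account therefore expects compound 4 to fall below compound 2, by a step estimated as a number at least 35 percentage points lower from compound 2 to compound 4 (beyond the scatter). The expected value for compound 4 in this assay is 35%, within 10% to 65%.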

Compound 4, a percentage reported as inhibition, at one concentration (the size of the read-out at that concentration, not a potency): 47%
Compound 4: middle estimate off by 12 percentage points, on the low side; measured number inside the range.
By their numbers in this assay, from the lowest: compound 1; then compound 3; then compound 4. At a limit, above all of these: compound 2.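

Within the data shown here, with compound 4, the amide-type nitrogen on this core gains its only directly readable change: 2-hydroxyethyl in place of cyclopentyl gives a number at least 23 percentage points lower from compound 2 to compound 4 (beyond the scatter) in this assay. The earlier step replaced a carboxy group on a different core and said nothing about cyclopentyl, whereas this one shows that losing cyclopentyl here costs inhibition, although compound 4 still gives 47% with no ring on that nitrogen. The full size of the loss remains unknown because compound 2 stands at a limit of the read-out rather than at an exact number: the limit of > 70% in this assay, at which 1 of the 4 values shown sits.

The change removes the ring and introduces the hydroxyl at once, so the compounds shown cannot tell which of the two accounts for the loss, and a plain ethyl or a cyclobutyl on the same nitrogen would help to separate them. They also leave open how a longer chain ending in hydroxyl, or a chain ending in an amine or a carboxylic acid, would read on this core.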